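The source may hold more compounds than are shown below. What is called first, only, known or untested is meant among the compounds shown, and "the series" means these compounds.

Measured in a functional assay on MCF7 cells (Homo sapiens) for antiproliferative activity, read by MTT assay, with a stated time of 48 h; a lower number here means a stronger inhibitor, a higher number a weaker inhibitor:
- compound 1 `O=C(/C=C/c1ccccn1)c1nc2ccccc2s1`: > 100000 nM (a limit, not a number)
- compound 2 `O=C(/C=C/c1ccccc1Br)c1nc2ccccc2[nH]1`: 50900 nM
- compound 3 `COc1cccc(/C=C/C(=O)c2nc3ccccc3[nH]2)c1`: 21700 nM

Of the two true numbers, compound 2 has the higher, 50900 nM. Compound 3 stands lower at 21700 nM, a gap beyond the usual scatter. Compound 4 `COc1ccccc1/C=C/C(=O)c1nc2ccccc2[nH]1` is still unmeasured and differs from compound 2 as follows: methoxy in place of bromo on an aromatic carbon. Methoxy replaces bromo on an aromatic carbon, ortho to a large group. Compound 3, which also carries methoxy, gives 21700 nM, so a modest step toward a lower number in this assay is expected, possibly not far beyond the scatter. The expected change is a 1.7-fold lower number from compound 2 to compound 4 (0.23 log units; within the scatter). The estimated value for compound 4 is 30000 nM, with an expected range of 12000 nM to 75000 nM.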

Compound 4, half-maximal inhibitory concentration: 41300 nM
The estimate for compound 4 lay 1.4-fold (0.14 log units) below the measured number; low and high end bracket the measured number.
By their numbers in this assay, from the lowest: compounds 3, 4 and 2 (each within the scatter of the next, the first and the last beyond it). At a limit, above all of these: compound 1.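

In this assay, among these compounds, this pair gives the first direct reading of a single change, on an aromatic carbon, ortho to a large group: methoxy in place of bromo gives a 1.2-fold lower number from compound 2 to compound 4 (0.09 log units; within the scatter). At this position, the two groups therefore cannot be told apart by this read-out, although they differ in heavy atoms and hydrogen-bond acceptors. Compound 1 gives a limit, not a number: the limit of > 100000 nM in this assay, at which 1 of the 4 values shown sits.

The compounds shown leave open whether an amine or a carboxylic acid on this carbon would separate from bromo and methoxy in this assay. They also leave open whether an unsubstituted ring carbon here would do so.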